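Replacing one triazole by another on a known inhibitor scaffold

The compounds below may be only part of what the source reports. "The series", "measured", "known", "first", "only" and "open" are said of these compounds alone.

Compound 2 `Cc1cc(C)c(NC(=O)N(Cc2ccc(-c3n[nH]c(C)n3)cc2)C2CCCCCC2)c(C)c1` and compound 1 `Cc1cc(C)c(NC(=O)N(Cc2ccc(-c3ccccc3)nc2)C2CCCCCC2)c(C)c1` share a core and differ only in the aromatic group carried at the far end of the benzylic arm. Among the measured compounds shown here, in an assay on microsomes from intestine for inhibition of acyl-CoA:cholesterol acyltransferase (Oryctolagus cuniculus) (on this read-out higher numbers stand for weaker inhibition and lower numbers for stronger inhibition), compound 2 gives 120 nM, the lowest of the two numbers known so far, and in this assay compound 1 gives 260 nM, a number that lies beyond the usual scatter above that of compound 2.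

Compound 3 `Cc1cc(C)c(NC(=O)N(Cc2ccc(-n3cncn3)cc2)C2CCCCCC2)c(C)c1` has not yet been measured. It differs from compound 2 in a single respect: 1H-1,2,4-triazol-1-yl in place of 5-methyl-1H-1,2,4-triazol-3-yl on an aromatic carbon. For the measured compounds named here, nothing among the measured pair tells how this kind of exchange is felt, so the expectation rests on the change alone. The step from compound 2 to compound 3 is expected to be small and, if anything, toward a weaker inhibition, a 1.7-fold higher number from compound 2 to compound 3 (0.22 log units; within the scatter). Compound 3 is therefore estimated at 200 nM, with a likely range from 70 nM to 600 nM.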

Compound 3, half-maximal inhibitory concentration: 26 nM
Compound 3: the middle estimate sits 7.7-fold (0.89 log units) above what was measured; measured number below the stated range.
By their numbers in this assay, from the lowest: compound 3; then compound 2; then compound 1.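

In this assay the exchange gives a 4.6-fold lower number from compound 2 to compound 3 (0.66 log units; beyond the scatter) at this place, on an aromatic carbon of a six-membered aromatic ring of carbon only and para to a large group, so the inhibition read here depends on which triazole sits there, although both groups are five-membered aromatic rings with 3 hetero atoms. The exchange alters several things at once: the entering group lacks the methyl and the hydrogen-bond donor of the leaving group, and it is attached through a ring nitrogen rather than a ring carbon. No measurement offered here accounts for the size of this step.

The pair cannot separate these differences, and a 1H-1,2,4-triazol-3-yl group without the methyl would be the direct test of the methyl's share. Going by these compounds, how an imidazol-1-yl group, an amine or a carboxylic acid would fare at this place also remains open.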